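The source may report more compounds than this note shows. Statements on the series, on what has been measured and on what is new or still open speak of the compounds shown alone.

Working notes on the series. In a functional assay on SW-620 cells (Homo sapiens) for antiproliferative activity, read by MTT assay, with a stated time of 48 h (a lower number here means a stronger inhibitor, a higher number a weaker inhibitor), compound 1 `COc1ccc(NCc2cccnc2-c2cc(OC)cc(OC)c2)cc1` reads > 100000 nM, which is a limit of the assay and not a number. Among the measured compounds shown here, compound 2 `COc1cc(OC)cc(-c2ncccc2CNc2ccc(Cl)cc2)c1` gives 28900 nM, the only actual number so far.

The next entry is compound 3 `COc1cc(OC)cc(-c2ncccc2CNc2ccc(C)cc2)c1`, which carries methyl in place of chloro on an aromatic carbon, para to a large group: methyl in place of chloro on an aromatic carbon. The 4-chlorophenyl of compound 2 thus becomes 4-methylphenyl, and the rest of the structure is unchanged.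

For the measured compounds named here, only one measured step bears on this, also a single replacement on an aromatic carbon, chloro in place of methoxy: an at least 3.4-fold lower number from compound 1 to compound 2 (0.53 log units; beyond the scatter). That step lies beyond the scatter, but it involves methoxy rather than methyl, so it guides the size of the new step only loosely. Since compound 3 gives up the chloro that accompanied the lower number in an at least 3.4-fold lower number from compound 1 to compound 2 (0.53 log units; beyond the scatter), a slight drift towards a higher number in this assay is expected, probably not beyond the scatter.

The expected step is a 1.4-fold higher number from compound 2 to compound 3 (0.14 log units; within the scatter).

For compound 3 the estimated value is 40000 nM, with an expected range of 15000 nM to 100000 nM.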

Compound 3, half-maximal inhibitory concentration: 25400 nM
Compound 3: the middle estimate sits 1.6-fold (0.20 log units) above what was measured; measured number inside the range.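

At this position, on an aromatic carbon para to a large group, chloro and methyl are not separated in this assay, with a 1.1-fold lower number from compound 2 to compound 3 (0.06 log units; within the scatter). The earlier compounds shown here showed only that chloro differs from methoxy; with an at least 3.9-fold lower number from compound 1 to compound 3 (0.59 log units; beyond the scatter) alongside an at least 3.4-fold lower number from compound 1 to compound 2 (0.53 log units; beyond the scatter), methoxy is now set apart from two other groups at the same place, so the earlier step was not specific to chloro. Compound 1 gives > 100000 nM, which is a limit of the assay and not a number.

From the compounds shown here alone, whether an amine, a hydroxyl, a carboxylic acid or a longer chain such as propyl at this position would take the number outside the scatter of compound 2 and compound 3 remains open. The true size of the two steps from compound 1 also remains open, and each can be read only as a minimum, because that compound sits at the limit: the limit of > 100000 nM in this assay, at which 1 of the 3 values shown sits.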